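Acylglycinamide variation on the chlorinated benzophenone core

The compounds below may be only part of what the source reports. "The series", "measured", "known", "first", "only" and "open" are said of these compounds alone.

Measured compounds in a functional assay on the whole organism for antagonist activity, with Mus musculus as the target; a lower number here means that less compound is needed, a higher number that more compound is needed for the effect:
compound 1 `NC(C(=O)NCC(=O)Nc1ccc(Cl)cc1C(=O)c1ccccc1)c1ccccc1` gives 28 mg/kg
compound 2 `CN(C(=O)CNC(=O)CN)c1ccc(Cl)cc1C(=O)c1ccccc1Cl` gives 0.58 mg/kg
compound 3 `CC(=O)NCC(=O)Nc1ccc(Cl)cc1C(=O)c1ccccc1` gives 37 mg/kg

Compound 2 stands lowest of the three measured numbers, with compound 1 nearest and compound 3 furthest, both beyond the scatter. Compound 2 and compound 4 `CC(C)C(=O)NCC(=O)N(C)c1ccc(Cl)cc1C(=O)c1ccccc1Cl` share the core of compound 2 and differ only in the acyl group on the glycinamide nitrogen: isopropyl in place of aminomethyl on a carbonyl carbon.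

Within the data shown here, the one measured step at the same place is a 1.3-fold higher number from compound 1 to compound 3 (0.12 log units; within the scatter), in which the acyl group was also exchanged and the amino group removed, without a change beyond the scatter. Among the measured compounds shown here, the exchange from compound 2 to compound 4 likewise removes the amino group and replaces it with a branched alkyl, so no step beyond the scatter is expected in this assay, though a small rise cannot be excluded given the single reference step.

Compound 4 is therefore expected to give 1 mg/kg in this assay, within 0.35 mg/kg to 3 mg/kg, which means an expected step of a 1.7-fold higher number from compound 2 to compound 4 (0.24 log units; within the scatter).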

Compound 4, dose for half-maximal effect: 6 mg/kg
Compound 4: middle estimate off by 6.0-fold (0.78 log units), on the low side; measured number outside the range, above it.
By their numbers in this assay, from the lowest: compound 2; then compound 4; then compounds 1 and 3 (each within the scatter of the next).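

In this assay, isopropyl in place of aminomethyl on a carbonyl carbon gives a 10-fold higher number from compound 2 to compound 4 (1.01 log units; beyond the scatter) and so shows that, on the core of compound 2, the outcome depends on the group at this place. The earlier exchange at this place, which gave a 1.3-fold higher number from compound 1 to compound 3 (0.12 log units; within the scatter) on a different core with different groups, showed no such dependence, so it does not carry over to this pair. No measurement shown accounts for the size of the new step.

The compounds shown do not separate the loss of the amine from the gain of branched alkyl, and a 2-aminoethyl or an ethyl group at this carbonyl carbon would bear on that question. On these data alone, whether the same exchange gives a step of similar size on the core of compound 1 also stays open.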